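Moving a methyl group around the ring in a thiadiazole series

A few compounds are considered here, and "the series" means these few. Any claim that something is new, unique, unknown or untested is made for them only; others in the source may bear on it.

Compound 1 `Cc1ccc(Nc2nnc(Nc3nc(-c4ccc(Cl)cc4)cs3)s2)cc1`: 300 mg/kg
Compound 2 `Cc1ccccc1Nc1nnc(Nc2nc(-c3ccc(Br)cc3)cs2)s1`: 300 mg/kg

Both compounds were tested in a functional assay on the whole organism (strain albino) with Mus musculus as the target, with a stated time of 4 h; a lower number here means that less compound is needed, a higher number that more compound is needed for the effect. Compound 1 gives 300 mg/kg in this assay, and compound 2 gives 300 mg/kg. Compound 2 therefore stands level with compound 1 at the digits shown, the two values lying within the usual scatter of one another.

Compound 3 `Cc1ccc(Nc2nnc(Nc3nc(-c4ccc(Br)cc4)cs3)s2)cc1` has not yet been measured. It differs from compound 2 in one place: 4-methylphenyl in place of 2-methylphenyl on a nitrogen on an aromatic ring. Within the data shown here, no step between measured compounds that differ in this one place has been recorded, so the expectation rests on the two values seen so far, which agree with each other.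

For compound 3 in this assay a step of no change at the digits printed from compound 2 to compound 3 (within the scatter) is expected, that is, no change beyond the scatter. Compound 3 is estimated to give 300 mg/kg, with a range from 150 mg/kg to 600 mg/kg.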

Compound 3, minimum effective dose: 300 mg/kg
Beside the measured number, compound 3's estimate shows no gap at the digits printed, within the range that was stated.
By their numbers in this assay, from the lowest: compounds 1, 2 and 3 (each within the scatter of the next).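

Among these compounds, compound 3 gives the first direct comparison at this position: in this assay, 4-methylphenyl in place of 2-methylphenyl on the nitrogen gives no change at the digits printed from compound 2 to compound 3 (within the scatter), so these two placements of the methyl group cannot be told apart in this read-out. Among the compounds shown here, it also gives the first comparison of the two halogens, with bromo in place of chloro on an aromatic carbon giving no change at the digits printed from compound 1 to compound 3 (within the scatter) while the rest of the molecule stays the same. No independent measurement is available to explain either result.

From the compounds shown here alone, all three compounds share one value, so it remains unknown whether any change at these two places can shift the dose needed. An amine, a carboxylic acid or a longer chain in place of the methyl group could test this.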